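The compounds below may be only part of what the source reports. "The series", "measured", "known", "first", "only" and "open" are said of these compounds alone.

In a functional assay on MCF7 cells (Homo sapiens) for antiproliferative activity, read by MTT assay, with a stated time of 72 h (on this read-out higher numbers stand for weaker inhibition and lower numbers for stronger inhibition), compound 1 `Nc1nc(N)c2cc(CSC(=S)N3CCN(c4ccccc4)CC3)ccc2n1` gives 2950 nM and compound 2 `COc1ccc(N2CCN(C(=S)SCc3ccc4nc(N)nc(N)c4c3)CC2)cc1` gives 1580 nM, so compound 2 stands within the usual scatter of compound 1. Compound 3 `Cc1ccc(N2CCN(C(=S)SCc3ccc4nc(N)nc(N)c4c3)CC2)cc1` differs from compound 2 in one group: methyl in place of methoxy on an aromatic carbon. This puts methyl in place of methoxy on an aromatic carbon, para to a large group. Going by the values given here, the one measured step that bears on this, a 1.9-fold lower number from compound 1 to compound 2 (0.27 log units; within the scatter), puts methoxy in place of hydrogen, so no change beyond the scatter is expected in this assay. The expected step is a 1.3-fold higher number from compound 2 to compound 3 (0.10 log units; within the scatter). For compound 3 the estimated value is 2000 nM, with an expected range of 900 nM to 4500 nM.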

Compound 3, half-maximal inhibitory concentration: 2480 nM
Beside the measured number, compound 3's estimate is 1.2-fold (0.09 log units) below it, and the stated range covers the measured number.
By their numbers in this assay, from the lowest: compounds 2, 3 and 1 (each within the scatter of the next).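

With methyl at this place, this assay gives a 1.6-fold higher number from compound 2 to compound 3 (0.20 log units; within the scatter) and also a 1.2-fold lower number from compound 1 to compound 3 (0.08 log units; within the scatter), both within the scatter. Hydrogen, methoxy and methyl on this aromatic carbon therefore cannot be told apart in this assay, so a methyl, like a methoxy, leaves the number about where the unsubstituted phenyl puts it. Nothing measured here offers an explanation for these small differences. Still open, going by these compounds, is whether an amine or a carboxylic acid at this place would move the number beyond the scatter. A longer chain, such as butyl, poses the same question.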